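This account rests on a few compounds, and the source may have more. Where it says the series, first, only, none or still open, it means among the compounds named here.

Working notes on a carbamate series in a physicochemical assay for lipophilicity; on this read-out lower numbers stand for lower lipophilicity and higher numbers for higher lipophilicity.

Compound 1 `CCCCCCCCNC(=O)Oc1ccc(Cl)cc1C(=O)Nc1cccc(Cl)c1` gives 6.36 in this assay. Compound 2 `CCCCCCCCCNC(=O)Oc1ccc(Cl)cc1C(=O)Nc1cccc(Cl)c1` gives 6.78. The change between them, (methyl in place of hydrogen on a saturated chain carbon, eight bonds along the chain from an amide-type nitrogen), made a step of a number 0.42 log units higher from compound 1 to compound 2 (beyond the scatter). Compound 3 `CCCCNC(=O)Oc1ccc(Cl)cc1C(=O)Nc1ccc(Cl)c(Cl)c1` gives 5.25, the lowest of the three numbers; the difference between the core of compound 3 and the core of compound 1 is not broken down here.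

Compound 4 `CCCCCNC(=O)Oc1ccc(Cl)cc1C(=O)Nc1ccc(Cl)c(Cl)c1` is not yet measured. It differs from compound 3 by methyl in place of hydrogen on a saturated chain carbon, four bonds along the chain from an amide-type nitrogen. This is the same kind of change as that from compound 1 to compound 2, not the same: there the methyl enters eight bonds along the chain from an amide-type nitrogen, here four bonds along the chain from an amide-type nitrogen. A step of about the same size is expected, a number 0.43 log units higher from compound 3 to compound 4 (beyond the scatter), resting on the step from compound 1 to compound 2 of a number 0.42 log units higher from compound 1 to compound 2 (beyond the scatter). Compound 4 is therefore expected to give 5.68, likely between 5.4 and 5.95.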

Compound 4, partition coefficient: 5.67
The estimate for compound 4 lay 0.01 log units above the measured number, within the range that was stated.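

In this assay, methyl in place of hydrogen gives a number 0.42 log units higher from compound 3 to compound 4 (beyond the scatter) on the core of compound 3, and the same kind of change gives a number 0.42 log units higher from compound 1 to compound 2 (beyond the scatter) on the core of compound 1, so the two printed steps match across these two cores. This is one pair per core, and core and chain place differ together, four bonds along the chain in one pair and eight in the other, so the separate contribution of each cannot be read and nothing is shown for any further core. No measurement here bears on why the two steps match.

Going by these compounds, whether an amine or a carboxylic acid in place of that hydrogen would carry across the two cores stays open. So does whether a longer chain on the core of compound 3 would continue the same step.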